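Working notes: from compound 2 toward compound 4

A few compounds are considered here, and "the series" means these few. Any claim that something is new, unique, unknown or untested is made for them only; others in the source may bear on it.

Three compounds carry numbers in a functional assay on cells (Cancer cell lines, Homo sapiens) for cytotoxicity, read by sulforhodamine B assay, with a stated time of 48 h; on this read-out lower numbers stand for stronger inhibition of growth and higher numbers for weaker inhibition of growth. Compound 1 `Oc1ccc(O)c(-c2cc(-c3ccccc3)nn2-c2ccccc2)c1` gives 77400 nM. Compound 2 `Oc1ccc(O)c(-c2cc(-c3ccc(Cl)cc3)nn2-c2ccccc2)c1` gives 16800 nM, the lowest of the three numbers. Compound 3 `CC(=O)NS(=O)(=O)c1ccc(-n2nc(-c3ccc(Cl)cc3)cc2-c2cc(O)ccc2O)cc1` gives 66600 nM. The two single-point steps among them are a 4.6-fold lower number from compound 1 to compound 2 (0.66 log units; beyond the scatter) and a 4.0-fold higher number from compound 2 to compound 3 (0.60 log units; beyond the scatter), each modest and each beyond the scatter, but both concern substituents on the outer aryl rings, not the group that carries the two hydroxyls.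

Compound 4 `O=C1C=CC(=O)C(c2cc(-c3ccc(Cl)cc3)nn2-c2ccccc2)=C1` differs from compound 2 in that change: a group of 8 heavy atoms (6 carbon, 2 oxygen; one six-membered non-aromatic ring of carbon only) in place of a group of 8 heavy atoms (6 carbon, 2 oxygen; one six-membered aromatic ring of carbon only), on an aromatic carbon. For the measured compounds named here, no measured step touches this group, so neither measured step bears on the change directly; the expectation can only be that the number moves by a modest amount, with the direction uncertain and a lower number weighed slightly more. For compound 4 in this assay the estimate is 10000 nM, with a range from 2500 nM to 50000 nM. This estimate means an expected step of a 1.7-fold lower number from compound 2 to compound 4 (0.23 log units; within the scatter).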

Compound 4, concentration for total growth inhibition: 69700 nM
Beside the measured number, compound 4's estimate is 7.0-fold (0.84 log units) below it; the measured number lies above the stated range.
By their numbers in this assay, from the lowest: compound 2; then compounds 3, 4 and 1 (each within the scatter of the next).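

In this assay, for the compounds shown here, the group on the aromatic carbon next to the ring nitrogen is not a silent position: with the heavy-atom count unchanged, the non-aromatic six-membered carbon ring in place of 2,5-dihydroxyphenyl gives a 4.1-fold higher number from compound 2 to compound 4 (0.62 log units; beyond the scatter) as the first measured step at this place. The entering group has 0 hydrogen-bond donors against 2 for the group that leaves, with 2 hydrogen-bond acceptors in each. Nothing available ties the step to those donors, to the loss of the aromatic ring or to any other feature of the group.

On these data alone, one pair cannot separate the two hydroxyls from the ring that carries them, so whether a methoxy group or an amine on the phenyl ring would hold the number of compound 2 stays open. Also open, as far as these compounds go, is whether the same change gives a step of like size on the core of compound 1 or compound 3.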